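The compounds below may be only part of what the source reports. "The series", "measured", "known", "first", "only" and "open" are said of these compounds alone.

Compound 1 `CC(C)(NC(=O)OCc1ccccc1)c1nc(O)c(O)c(C(=O)N/N=C/c2ccc(F)cc2)n1`: 378000 nM
Compound 2 `COCCNC(=O)Nc1nc(C(C)(C)NC(=O)OCc2ccccc2)nc(O)c1O`: only a limit, > 500000 nM

In an ADME assay on C8166 cells (Homo sapiens) for cytotoxicity, read by MTT assay, with a stated time of 3 days (a lower number here means that less compound is tolerated, a higher number that more compound is tolerated), compound 1 gives 378000 nM. Compound 2 gives no number here but only a limit, > 500000 nM, so it sits at the limit of > 500000 nM in this assay, at which 1 of the 2 values shown sits. Compound 3 `Cc1ccc(CNC(=O)c2nc(C(C)(C)NC(=O)OCc3ccccc3)nc(O)c2O)cc1` differs from compound 2 by (4-methylbenzyl)carbamoyl in place of ((2-methoxyethyl)carbamoyl)amino on an aromatic carbon. Among the measured compounds shown here, no measured step between these compounds is known, so the size of the change cannot be read from the data. Compound 3 is expected to be tolerated somewhat less than compound 2, with a step of an at least 1.6-fold lower number from compound 2 to compound 3 (0.22 log units; that floor lies within the scatter) estimated. Compound 3 is thus estimated at 300000 nM, within 100000 nM to 500000 nM.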

Compound 3, half-maximal cytotoxic concentration: 234000 nM
Estimate against measurement, compound 3: 1.3-fold (0.11 log units) above; low and high end bracket the measured number.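

In this assay, among the compounds shown here, (4-methylbenzyl)carbamoyl in place of ((2-methoxyethyl)carbamoyl)amino on this aromatic carbon gives an at least 2.1-fold lower number from compound 2 to compound 3 (0.32 log units; beyond the scatter), the first sign that a change at this position can move the number beyond the scatter. That size is only a floor, since compound 2 stands at a limit: the limit of > 500000 nM in this assay, at which 1 of the 3 values shown sits.
The change of group on the amide-type nitrogen gives a 1.6-fold lower number from compound 1 to compound 3 (0.21 log units; within the scatter), so that exchange does not separate the two compounds.

Going by these compounds, how far the true value of compound 2 lies from compound 3 stays open. So does whether a plain amine or a carboxylic acid on this aromatic carbon would shift the number at all.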